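Swapping a Small Ring for a Dimethylpyrazole

This account rests on a few compounds, and the source may have more. Where it says the series, first, only, none or still open, it means among the compounds named here.

Compound 1 `CN1CCN(CCCS(=O)(=O)c2ccc3nc(NC(=O)NC(=O)c4cc(C5CC5)ccc4Cl)sc3c2)CC1` is the starting point. In an assay on HEK293 cells for displacement of a labelled ligand from growth hormone secretagogue receptor type 1 (Homo sapiens), with a stated time of 60 min (on this read-out lower numbers stand for stronger inhibition and higher numbers for weaker inhibition), compound 1 gives 0.33 nM. Among the measured compounds shown here, its only companion is compound 2 `CN1CCN(CCCS(=O)(=O)c2ccc3nc(NC(=O)NC(=O)c4cc(N5CCCC5)c(C#N)cc4Cl)sc3c2)CC1`, which carries different substituents on the same part of the shared core; in this assay compound 2 gives 0.24 nM. Of the two numbers, compound 1 has the higher one, but the gap to compound 2 lies within the scatter, so the two values cannot be told apart.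

Compound 3 `Cc1cc(C)n(-c2ccc(Cl)c(C(=O)NC(=O)Nc3nc4ccc(S(=O)(=O)CCCN5CCN(C)CC5)cc4s3)c2)n1` has not yet been measured. It differs from compound 1 in one place: 3,5-dimethyl-1H-pyrazol-1-yl in place of cyclopropyl on an aromatic carbon.

For the measured compounds named here, no measured pair of compounds with a single change is available, so the size of this step cannot be taken from a known example. Compound 2 shows that a different substituent in this part of the molecule still gives a very low number in this assay. On that basis compound 3 is expected to stay close to compound 1, with a step of a 1.2-fold higher number from compound 1 to compound 3 (0.08 log units; within the scatter) that is not beyond the scatter. The estimate for compound 3 in this assay is 0.4 nM, within a range from 0.15 nM to 1.2 nM.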

Compound 3, half-maximal inhibitory concentration: 1.3 nM
The estimate for compound 3 lay 3.3-fold (0.51 log units) below the measured number, outside the stated range (above it).
By their numbers in this assay, from the lowest: compounds 2 and 1 (each within the scatter of the next); then compound 3.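

In this assay, among the compounds shown here, replacing cyclopropyl with 3,5-dimethyl-1H-pyrazol-1-yl gives a 3.9-fold higher number from compound 1 to compound 3 (0.60 log units; beyond the scatter) and so provides the first single-change evidence that the number responds to what sits on this aromatic carbon, para to the chloro group. The entering group has 7 heavy atoms against 3 and 2 hydrogen-bond acceptors against 0, and compound 3 gives 1.3 nM and thus keeps a low number despite this modest rise. No measurement here explains the step, and a single pair cannot separate the effects of the added methyl groups, the ring nitrogens and the overall size of the new group.

As far as these compounds go, it remains open whether the plain 1H-pyrazol-1-yl group, without its two methyl groups, or a small amine such as dimethylamino on the same carbon would give a number closer to that of compound 1. From the compounds shown here alone, it is also open whether the same swap would give a step of similar size on a core carrying different groups elsewhere.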